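The source may hold more compounds than are shown below. What is called first, only, known or untested is meant among the compounds shown, and "the series" means these compounds.

Compound 1 `Cc1cccc(Cl)c1NC(=O)c1cc2ccccc2oc1=O`: 19100 nM. Compound 2 `COc1cc(NC(=O)c2cc3ccc(OCc4ccccc4)cc3oc2=O)cc(OC)c1`: 3360 nM. Compound 3 `Cc1cccc(Cl)c1NC(=O)c1cc2ccc(OCc3ccc(F)cc3)cc2oc1=O`: 41600 nM.

In an in vitro assay on BTI-TN-5B1-4 cells for inhibition of Amine oxidase [flavin-containing] B (Homo sapiens), read by fluorescence (a higher number here means a weaker inhibitor, a lower number a stronger inhibitor), compound 3 gives the highest of the three numbers; compound 1 stands nearest and compound 2 furthest. For the measured compounds named here, the only single-point step measured, a 2.2-fold higher number from compound 1 to compound 3 (0.34 log units; beyond the scatter), concerns the (4-fluorobenzyl)oxy group and does not touch the amide-type nitrogen. Compound 4 `COc1cc(NC(=O)c2cc3ccc(OCc4ccc(F)cc4)cc3oc2=O)cc(OC)c1` differs from compound 3 by 3,5-dimethoxyphenyl in place of 2-chloro-6-methylphenyl on an amide-type nitrogen. Going by the values given here, no measured step carries that change alone. Compound 2 shares the 3,5-dimethoxyphenyl group with compound 4, and in this assay compound 2 gives 3360 nM, far below compound 3. Compound 4 is therefore expected to sit well below compound 3. The expected step is a 9.2-fold lower number from compound 3 to compound 4 (0.97 log units; beyond the scatter). The estimate for compound 4 is 4500 nM, with a range of 1500 nM to 13000 nM.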

Compound 4, half-maximal inhibitory concentration: 21600 nM
Compound 4: the middle estimate sits 4.8-fold (0.68 log units) below what was measured; measured number above the stated range.
By their numbers in this assay, from the lowest: compound 2; then compounds 1, 4 and 3 (each within the scatter of the next, the first and the last beyond it).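

In this assay, 3,5-dimethoxyphenyl in place of 2-chloro-6-methylphenyl on the amide-type nitrogen gives a 1.9-fold lower number from compound 3 to compound 4 (0.28 log units; within the scatter) and stays within the scatter, so with the (4-fluorobenzyl)oxy group present this change does not separate the two compounds. With 3,5-dimethoxyphenyl held fixed, fluoro in place of hydrogen on an aromatic carbon gives a 6.4-fold higher number from compound 2 to compound 4 (0.81 log units; beyond the scatter) and so accounts for the larger gap. Nothing measured here explains either step.

The compounds shown leave open how 2-chloro-6-methylphenyl behaves alongside a plain benzyl ether. They also leave open what a morpholine or a carboxylic acid-bearing phenyl would do on the amide-type nitrogen.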